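A few compounds are considered here, and "the series" means these few. Any claim that something is new, unique, unknown or untested is made for them only; others in the source may bear on it.

Series notes for a functional assay on A549 cells (Homo sapiens) for cytotoxicity, read by MTT assay, with a stated time of 24 h; on this read-out higher numbers stand for weaker inhibition and lower numbers for stronger inhibition: compound 1 `C/C(=N\NC(=O)/C(C#N)=C/c1ccccc1)c1c(O)c2ccc(O)cc2oc1=O` gives 14800 nM, compound 2 `C/C(=N\NC(=O)/C(C#N)=C/c1ccc(O)cc1)c1c(O)c2ccc(O)cc2oc1=O` gives 6230 nM and compound 3 `COc1ccc(/C=C(\C#N)C(=O)N/N=C(\C)c2c(O)c3ccc(O)cc3oc2=O)cc1OC` gives 14300 nM. Two numbers sit together and one lies apart, with compound 3 in the pair: the steps read a 1.0-fold lower number from compound 1 to compound 3 (0.01 log units; within the scatter) and a 2.3-fold higher number from compound 2 to compound 3 (0.36 log units; beyond the scatter). Compound 4 `COc1ccc(/C=C(\C#N)C(=O)N/N=C(\C)c2c(O)c3ccc(O)cc3oc2=O)cc1` has hydrogen in place of methoxy on an aromatic carbon, taking 3,4-dimethoxyphenyl to 4-methoxyphenyl. The phenyl and 3,4-dimethoxyphenyl ends already match within the scatter, and the remaining step, a 2.4-fold lower number from compound 1 to compound 2 (0.38 log units; beyond the scatter), comes with a hydroxy that the new structure does not carry. No step beyond the scatter is therefore expected in this assay. The expected step is a 1.2-fold lower number from compound 3 to compound 4 (0.08 log units; within the scatter). For compound 4 the estimated value is 12000 nM, with an expected range of 6000 nM to 22000 nM.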

Compound 4, half-maximal inhibitory concentration: 8150 nM
Compound 4: middle estimate off by 1.5-fold (0.17 log units), on the high side; the range from low to high includes it.
By their numbers in this assay, from the lowest: compounds 2, 4, 3 and 1 (each within the scatter of the next, the first and the last beyond it).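

Taking this methoxy off gives a 1.8-fold lower number from compound 3 to compound 4 (0.24 log units; within the scatter) in this assay and so no readable change at this position. Methyl on the hydroxy oxygen gives a 1.3-fold higher number from compound 2 to compound 4 (0.12 log units; within the scatter) and methoxy on the bare phenyl gives a 1.8-fold lower number from compound 1 to compound 4 (0.26 log units; within the scatter) and neither step separates the compounds. Compound 4 thus lies within the scatter of all three others, although compound 1 and compound 2 stand apart from each other. No measurement at hand explains these steps. On these data alone, whether an amine or a carboxylic acid on this aromatic carbon would give a step beyond the scatter stays open.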